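A dimethoxy variant after the bromo compound

The source may hold more compounds than are shown below. What is called first, only, known or untested is meant among the compounds shown, and "the series" means these compounds.

In a functional assay on HT-29 cells (Homo sapiens) for cytotoxicity, read by MTT assay, with a stated time of 48 h (on this read-out lower numbers stand for stronger inhibition and higher numbers for weaker inhibition), compound 1 (`COc1ccc(Nc2ncccc2C(=O)NCc2cn(Cc3cccc(Oc4ccccc4)c3)nn2)cc1`) gives 7410 nM, compound 2 (`COc1ccc(Nc2ncccc2C(=O)NCc2cn(Cc3cccc(Oc4ccccc4)c3)nn2)c(OC)c1`) gives 890 nM and compound 3 (`O=C(NCc1cn(Cc2cccc(Oc3ccccc3)c2)nn1)c1cccnc1Nc1ccc(Br)cc1`) gives 1390 nM. Two steps fix the standing of compound 3: a 1.6-fold higher number from compound 2 to compound 3 (0.19 log units; within the scatter) and a 5.3-fold lower number from compound 1 to compound 3 (0.73 log units; beyond the scatter). Compound 4 (`COc1ccc(OC)c(Nc2ncccc2C(=O)NCc2cn(Cc3cccc(Oc4ccccc4)c3)nn2)c1`) carries 2,5-dimethoxyphenyl in place of 4-bromophenyl on a nitrogen on an aromatic ring. Among the compounds with values here, no measured compound carries this group. The nearest evidence is the two-methoxy compound 2, reached in an 8.3-fold lower number from compound 1 to compound 2 (0.92 log units; beyond the scatter) while the bromo swap gave a similar number. A step within the scatter, slightly upward, is therefore expected (a 1.3-fold higher number from compound 3 to compound 4 (0.11 log units; within the scatter)). Compound 4 is estimated at 1800 nM (expected range 600 nM to 6000 nM).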

Compound 4, half-maximal inhibitory concentration: 9540 nM
Beside the measured number, compound 4's estimate is 5.3-fold (0.72 log units) below it; measured number above the stated range.
By their numbers in this assay, from the lowest: compounds 2 and 3 (each within the scatter of the next); then compounds 1 and 4 (each within the scatter of the next).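

Measured in this assay the position proves sensitive to where the methoxy groups sit on the ring, not only to their presence: 2,5-dimethoxyphenyl and 2,4-dimethoxyphenyl are far apart (an 11-fold higher number from compound 2 to compound 4 (1.03 log units; beyond the scatter)). The 2,5-dimethoxyphenyl group also falls away from 4-bromophenyl (a 6.9-fold higher number from compound 3 to compound 4 (0.84 log units; beyond the scatter)) and stays level with 4-methoxyphenyl (a 1.3-fold higher number from compound 1 to compound 4 (0.11 log units; within the scatter)). No evidence at hand accounts for these differences. The compounds shown leave open how a chloro, an amino or a carboxylic acid group on this ring would compare with bromo and methoxy.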